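The compounds below may be only part of what the source reports. "The series", "measured", "known", "first", "only" and "open" are said of these compounds alone.

In an assay on isolated protein for inhibition of Calpain-1 catalytic subunit (Homo sapiens) (a lower number here means a stronger inhibitor, a higher number a weaker inhibitor), compound 1 `CCC(NC(=O)C(CC(C)C)NC(=O)OCc1ccccc1)C(=O)C(=O)NCc1ccc2ccccc2n1` gives 130 nM. Compound 2 `CCNC(=O)C(=O)C(CC)NC(=O)C(CC(C)C)NC(=O)c1ccc2ccccc2n1` gives 500 nM in this assay, the higher of the two numbers, with compound 1 sitting beyond the scatter below it. Compound 3 `CCNC(=O)C(=O)C(CC)NC(=O)C(CC(C)C)NC(=O)c1nccc2ccccc12` differs from compound 2 by isoquinolin-1-yl in place of quinolin-2-yl on a carbonyl carbon. Among the measured compounds shown here, no measured pair shows this exchange, so there is no step to lean on; the two structures have the same atoms, joined differently, and a small shift is expected, probably none beyond the scatter. Compound 3 is therefore estimated at 600 nM, within 200 nM to 1800 nM. That estimate means an expected step of a 1.2-fold higher number from compound 2 to compound 3 (0.08 log units; within the scatter) inside the scatter.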

Compound 3, inhibition constant: 350 nM
Estimate against measurement, compound 3: 1.7-fold (0.23 log units) above, and the stated range covers the measured number.
By their numbers in this assay, from the lowest: compound 1; then compounds 3 and 2 (each within the scatter of the next).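

In this assay, isoquinolin-1-yl in place of quinolin-2-yl on a carbonyl carbon gives a small change (a 1.4-fold lower number from compound 2 to compound 3 (0.15 log units; within the scatter)). Among the compounds shown here, this is the first pair that differs at this position, and it shows that the two groups, with the same atoms joined differently, cannot be told apart here. Nothing available explains this result.

Going by these compounds, whether phenyl or pyridin-2-yl on this carbonyl carbon would shift the number beyond the scatter remains open. So does the effect of an amine on the isoquinolin-1-yl group.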